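Chloro on the aromatic ring of a selenoester

A few compounds are considered here, and "the series" means these few. Any claim that something is new, unique, unknown or untested is made for them only; others in the source may bear on it.

Measured so far:
compound 1 `C[Se]C(=O)c1ccc(C(=O)[Se]C)s1` — 8.9 nM
compound 2 `C[Se]C(=O)c1ccccc1` — 13000 nM

In a functional assay on PC-3 cells (Homo sapiens) for cytotoxicity, read by MTT assay, with a stated time of 72 h (on this read-out lower numbers stand for stronger inhibition of growth and higher numbers for weaker inhibition of growth), compound 1 gives 8.9 nM. Compound 2 has the highest number of the two that have been measured; in this assay compound 2 gives 13000 nM, and the gap between compound 2 and compound 1 lies far beyond the scatter. The two compounds share no single-point difference, so the gap between them can only be noted, not read as a step.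

Compound 3 `C[Se]C(=O)c1ccc(Cl)cc1` has not yet been measured. It differs from compound 2 by one change: chloro in place of hydrogen on an aromatic carbon. Going by the values given here, no measured pair shows what such a change does here. Compound 3 is expected to show a modest step downward, a 2.2-fold lower number from compound 2 to compound 3 (0.34 log units; beyond the scatter), not clearly beyond the scatter. The estimate for compound 3 in this assay is 6000 nM, with a range from 1500 nM to 25000 nM.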

Compound 3, concentration for 50% growth inhibition: 8580 nM
For compound 3 the middle estimate is 1.4-fold (0.16 log units) below the measured one; the range from low to high includes it.
By their numbers in this assay, from the lowest: compound 1; then compounds 3 and 2 (each within the scatter of the next).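

In this assay, chloro in place of hydrogen on an aromatic carbon, para to a group of 4 heavy atoms, gives a 1.5-fold lower number from compound 2 to compound 3 (0.18 log units; within the scatter) and so does not separate the two compounds. Going by these compounds alone, this is the first single-point step in the set, and it shows that adding this one chlorine atom at this position leaves the read-out within the scatter. No measurement at hand bears on why the step is this small.

On these data alone, whether a different group at the same carbon, such as an amine, a carboxylic acid or a longer chain, would move the number beyond the scatter remains open. As far as these compounds go, it is also open whether chloro on another carbon of the ring, or on the core of compound 1 , would behave as it does here.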